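Bromoaniline sulfonamide: predicted receptor binding at one concentration

The compounds below may be only part of what the source reports. "The series", "measured", "known", "first", "only" and "open" are said of these compounds alone.

Measured compounds:
- compound 1, `COc1cc(N)c(Cl)cc1C(=O)CCC1CCN(CCNS(=O)(=O)c2ccc(NC(C)=O)cc2)CC1`: 67%
- compound 2, `COc1cc(N)c(Cl)cc1C(=O)CCC1CCN(CCNS(=O)(=O)c2cc(Br)c(N)c(Br)c2)CC1`: 83%
- compound 3, `COc1ccc(S(=O)(=O)NCCN2CCC(CCC(=O)c3cc(Cl)c(N)cc3OC)CC2)cc1Br`: 72%

In an assay on HEK293 cells for displacement of a labelled ligand from 5-hydroxytryptamine receptor 6 (Homo sapiens), with a stated time of 60 min, tested at 1 uM, in the presence of a further agent that is not named here (a higher number here means a stronger effect of the compound at the concentration tested, a lower number a weaker effect), compound 1 gives 67%, the lowest of the three numbers. Compound 3 stands nearest, with a number 5 percentage points higher from compound 1 to compound 3 (within the scatter), while compound 2 stands furthest, with a number 16 percentage points higher from compound 1 to compound 2 (beyond the scatter). Between them lies a number 11 percentage points lower from compound 2 to compound 3 (beyond the scatter).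

Compound 4, `COc1cc(N)c(Cl)cc1C(=O)CCC1CCN(CCNS(=O)(=O)c2ccc(N)c(Br)c2)CC1`, is not yet measured. It differs from compound 1 at one place: 4-amino-3-bromophenyl in place of 4-acetamidophenyl on a sulfonyl sulfur. The group that enters shares the amine of compound 2 and a single bromine, as in compound 3, so both steps from compound 1 bear on the change. The step to compound 2 was modest and beyond the scatter; the step to compound 3 lay within it. A modest rise in this assay is therefore expected for compound 4, probably smaller than that seen for compound 2. The expected step is a number 11 percentage points higher from compound 1 to compound 4 (beyond the scatter). Compound 4 is estimated to give 78%, with a range from 66% to 90%.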

Compound 4, a percentage reported as inhibition, at one concentration (the size of the read-out at that concentration, not a potency): 85%
The estimate for compound 4 lay 7 percentage points below the measured number; low and high end bracket the measured number.
By their numbers in this assay, from the lowest: compounds 1 and 3 (each within the scatter of the next); then compounds 2 and 4 (each within the scatter of the next).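

In this assay, the step of a number 13 percentage points higher from compound 3 to compound 4 (beyond the scatter) isolates the amino group in place of methoxy on an aromatic carbon, with the single bromine held constant, and so shows that this exchange alone moves the read-out. Hydrogen in place of bromo gives a number 2 percentage points higher from compound 2 to compound 4 (within the scatter) and shows that the second bromine of compound 2 is not needed to keep the read-out at this concentration, while the step of a number 18 percentage points higher from compound 1 to compound 4 (beyond the scatter) shows that 4-amino-3-bromophenyl on the sulfonyl sulfur also outperforms 4-acetamidophenyl. No measurement shown here accounts for these differences.

The compounds shown leave open what a 4-aminophenyl group with no bromine, or with chlorine in place of the bromine, would give. A single concentration also leaves the potency of compound 4 and compound 2 unresolved.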